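The compounds below may be only part of what the source reports. "The series", "measured", "known", "first", "only" and "open" are said of these compounds alone.

Compound 1 `COc1ccccc1C(=O)OC1CCC(CN2CCN(c3cc(=O)c4cc(C(F)(F)F)cc([N+](=O)[O-])c4s3)CC2)CC1`, compound 2 `O=C(OC1CCC(CN2CCN(c3cc(=O)c4cc(C(F)(F)F)cc([N+](=O)[O-])c4s3)CC2)CC1)c1ccco1` and compound 3 `O=C(OC1CCC(CN2CCN(c3cc(=O)c4cc(C(F)(F)F)cc([N+](=O)[O-])c4s3)CC2)CC1)c1cccs1` share one core and differ only in the group on the carbonyl carbon. In an ADME assay on Vero cells (Chlorocebus sabaeus) for cytotoxicity, read by MTT assay, with a stated time of 48 h (on this read-out lower numbers stand for stronger inhibition and higher numbers for weaker inhibition), compound 1 reaches only a limit, > 64 ug/mL. Compound 2 likewise gives a limit, > 64 ug/mL. Compound 3 also stands at a limit, > 64 ug/mL, so on the numbers shown it sits at the boundary and no higher placing can be read. The steps a step that the two limits leave unreadable from compound 1 to compound 2, a step that the two limits leave unreadable from compound 1 to compound 3 and a step that the two limits leave unreadable from compound 2 to compound 3 cannot be sized because of the limit of > 64 ug/mL in this assay, at which 3 of the 3 values shown sit. Compound 4 `COc1ccc(C(=O)OC2CCC(CN3CCN(c4cc(=O)c5cc(C(F)(F)F)cc([N+](=O)[O-])c5s4)CC3)CC2)cc1` follows from compound 3 by 4-methoxyphenyl in place of thiophen-2-yl on a carbonyl carbon. Within the data shown here, the measured steps bear on this change only by showing that exchanges on the carbonyl carbon have brought no compound into the readable range. Compound 4 is therefore expected to remain at the limit, with a step that the limit leaves unreadable from compound 3 to compound 4 estimated as no step beyond the scatter. The estimate for compound 4 is 90 ug/mL, from 40 ug/mL to 250 ug/mL.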

Compound 4, half-maximal inhibitory concentration: > 64 ug/mL
Compound 4 ended at the assay's limit; the forecaster's own chance of this, stated with the estimate: 85%; the middle value lies beyond the limit too.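

No step between compound 4 and compound 1, compound 2 or compound 3 can be read in this assay, and the values give only the limit: the limit of > 64 ug/mL in this assay, at which 4 of the 4 values shown sit.

The compounds shown leave open whether any group on the carbonyl carbon brings a value into the readable range.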